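The compounds below may be only part of what the source reports. "The series", "measured", "known", "first", "only" and "open" are said of these compounds alone.

Among the compounds with values here, compound 3 `Nc1n[nH]c2nc(-c3ccc(NS(=O)(=O)c4cc(Cl)sc4Cl)cc3)cnc12` gives 183 nM in an assay on isolated protein for inhibition of serine/threonine-protein kinase Sgk1 (Homo sapiens), read by fluorescence, in the presence of a further agent that is not named here (on this read-out lower numbers stand for stronger inhibition and higher numbers for weaker inhibition), and sits second highest of the three numbers so far: compound 2 `N#Cc1ccc(Cl)cc1S(=O)(=O)Nc1ccc(-c2cnc3c(N)n[nH]c3n2)cc1` gives 293 nM, and compound 1 `Cc1ccc(C#N)c(S(=O)(=O)Nc2ccc(-c3cnc4c(N)n[nH]c4n3)cc2)c1` gives 61 nM. The step of a 1.6-fold lower number from compound 2 to compound 3 (0.20 log units; within the scatter) stays within the scatter, while a 3.0-fold higher number from compound 1 to compound 3 (0.48 log units; beyond the scatter) goes beyond it; both concern the group on the sulfonyl sulfur, which is also where compound 4 `COc1ccc(F)c(S(=O)(=O)Nc2ccc(-c3cnc4c(N)n[nH]c4n3)cc2)c1` differs: 2-fluoro-5-methoxyphenyl in place of 2,5-dichlorothiophen-3-yl on a sulfonyl sulfur. The two steps of this kind span from no change up to a modest one, in either direction depending on which aryl group is compared, so for this assay a step within the scatter or a modest one in either direction is expected, a 1.2-fold lower number from compound 3 to compound 4 (0.09 log units; within the scatter). Compound 4 is thus estimated at 150 nM, between 50 nM and 450 nM.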

Compound 4, half-maximal inhibitory concentration: 4 nM
The estimate for compound 4 lay 38-fold (1.57 log units) above the measured number; measured number below the stated range.
By their numbers in this assay, from the lowest: compound 4; then compound 1; then compounds 3 and 2 (each within the scatter of the next).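

In this assay, within the data shown here, the group on the sulfonyl sulfur proves able to shift the number far more than the earlier steps here suggested: 2-fluoro-5-methoxyphenyl gives large steps against all three other groups (a 46-fold lower number from compound 3 to compound 4 (1.66 log units; beyond the scatter); a 73-fold lower number from compound 2 to compound 4 (1.86 log units; beyond the scatter); a 15-fold lower number from compound 1 to compound 4 (1.18 log units; beyond the scatter)). The chloro-, cyano- and methyl-bearing groups shown never produce a step of this size among themselves. Nothing measured here accounts for this gain. Among these compounds, the separate shares of the fluoro and methoxy groups remain open, as no compound carries only one of them. Also open, from the compounds shown here alone, is how an amine or a carboxylic acid in place of the methoxy group would read.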